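The source may report more compounds than this note shows. Statements on the series, on what has been measured and on what is new or still open speak of the compounds shown alone.

In an ADME assay on Vero cells (Chlorocebus sabaeus) for cytotoxicity, read by resazurin assay, with a stated time of 24 h (a lower number here means that less compound is tolerated, a higher number that more compound is tolerated), compound 2 `CCCCO[C@@H]1C=CC(=O)[C@@H](COC(=O)C(C)(C)C)O1` stands highest of the two measured compounds at 42500 nM, while compound 1 `CCCCCO[C@@H]1C=CC(=O)[C@@H](COC(=O)C(C)(C)C)O1` gives 7380 nM. Compound 3 `CCCCCCO[C@@H]1C=CC(=O)[C@@H](COC(=O)C(C)(C)C)O1` differs from compound 2 by ethyl in place of hydrogen on a saturated chain carbon, four bonds along the chain from an oxygen on a saturated carbon. Among the compounds with values here, the only measured step at this place is a 5.8-fold higher number from compound 1 to compound 2 (0.76 log units; beyond the scatter), with hydrogen in place of methyl. Compound 3 instead adds carbon there, so on that single step a number lower than that of compound 2 is expected, by at least a similar size. The expected change is a 17-fold lower number from compound 2 to compound 3 (1.23 log units; beyond the scatter). Compound 3 is estimated at 2500 nM, with an expected range of 800 nM to 7500 nM.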

Compound 3, half-maximal cytotoxic concentration: 4800 nM
Compound 3: the middle estimate sits 1.9-fold (0.28 log units) below what was measured; the range from low to high includes it.
By their numbers in this assay, from the lowest: compounds 3 and 1 (each within the scatter of the next); then compound 2.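

In this assay, ethyl in place of hydrogen at this position gives an 8.9-fold lower number from compound 2 to compound 3 (0.95 log units; beyond the scatter) and so stands beyond the scatter, as the step between compound 1 and compound 2 did. Methyl in place of hydrogen, five bonds along the chain, gives a 1.5-fold lower number from compound 1 to compound 3 (0.19 log units; within the scatter) and stands within the scatter, so the pentyl and hexyl chains of compound 1 and compound 3 cannot be told apart here. Open, going by these compounds, is whether a longer chain than that of compound 3 would read the same, and how an amine or a carboxylic acid on the chain would read. No measurement at hand accounts for either step.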